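From triazole side chain to hydroxypiperidine chain

The source may report more compounds than this note shows. Statements on the series, on what has been measured and on what is new or still open speak of the compounds shown alone.

In a functional assay on A-375 cells (Homo sapiens) for cytotoxicity, read by MTT assay, with a stated time of 72 h (on this read-out higher numbers stand for weaker inhibition and lower numbers for stronger inhibition), compound 2 (`O=C1c2c[n+]([O-])c3ccccc3c2C(=O)c2c1c1ccccc1n2Cc1cn(C[C@@H](O)CO)nn1`) gives 140 nM as the lower of the two measured numbers, and compound 1 (`CN(C)CCCCCn1c2c(c3ccccc31)C(=O)c1c[n+]([O-])c3ccccc3c1C2=O`) gives 560 nM by comparison. Compound 3 (`O=C1c2c[n+]([O-])c3ccccc3c2C(=O)c2c1c1ccccc1n2CCCN1CCC(O)CC1`) carries 2-(4-hydroxypiperidin-1-yl)ethyl in place of 1-(2,3-dihydroxypropyl)-1H-1,2,3-triazol-4-yl on a saturated chain carbon bound to an aromatic nitrogen. Among the measured compounds shown here, the one measured step bearing on this (a 4.0-fold lower number from compound 1 to compound 2 (0.60 log units; beyond the scatter)) was modest and brought that triazole group in, so removing it should partly return towards a higher number. The expected change is modest (a 2.1-fold higher number from compound 2 to compound 3 (0.33 log units; beyond the scatter)) by this estimate. The estimate for compound 3 is 300 nM within an expected range of 90 nM to 900 nM on this single comparison.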

Compound 3, half-maximal inhibitory concentration: 240 nM
Compound 3: the middle estimate sits 1.3-fold (0.10 log units) above what was measured; measured number inside the range.
By their numbers in this assay, from the lowest: compounds 2 and 3 (each within the scatter of the next); then compound 1.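

In this assay, the step of a 1.7-fold higher number from compound 2 to compound 3 (0.23 log units; within the scatter) shows that this position tolerates two very different side chains: the 1-(2,3-dihydroxypropyl)-1H-1,2,3-triazol-4-yl group and the 2-(4-hydroxypiperidin-1-yl)ethyl group cannot be told apart here. The step of a 2.3-fold lower number from compound 1 to compound 3 (0.37 log units; beyond the scatter) shows that a triazole is not required to get below the number of compound 1, since 4-hydroxypiperidin-1-yl in place of 2-(dimethylamino)ethyl also does so. No supporting measurement here explains these numbers. The compounds shown leave open what the hydroxyl on the piperidine ring contributes, which a chain ending in plain piperidine or morpholine would test.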